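Furan-3-yl in place of vinyl on compound 2

The compounds below may be only part of what the source reports. "The series", "measured", "known", "first", "only" and "open" are said of these compounds alone.

Among the measured compounds shown here, in a functional assay on CUTLL1 cells (Homo sapiens) for inhibition, read by resazurin assay, with a stated time of 48 h, in the absence of a further agent (a lower number here means that less compound is needed, a higher number that more compound is needed for the effect), compound 2 `C=Cc1cnccc1-c1cnc(N)nc1C1CC1` gives 30000 nM and holds the only true number so far. Compound 1 `Nc1ncc(-c2ccc(F)cc2)c(C2CC2)n1` gives > 100000 nM in this assay and this is a limit of the assay, not a number. The next compound to be tested is compound 3 `Nc1ncc(-c2ccncc2-c2ccoc2)c(C2CC2)n1` with the same shared core as compound 2. It has furan-3-yl in place of vinyl on an aromatic carbon, ortho to a large group and two atoms from the ring nitrogen (furan-3-yl in place of vinyl on an aromatic carbon). For the measured compounds named here, no measured step between two compounds yet shows how large such a change can be. Starting from compound 2 at 30000 nM only a small move toward a lower number is expected, and the expected 1.7-fold lower number from compound 2 to compound 3 (0.22 log units; within the scatter) may stay within the usual scatter. In this assay compound 3 is estimated at 18000 nM with 5000 nM to 60000 nM as its expected range.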

Compound 3, half-maximal effective concentration: 28000 nM
Compound 3: the middle estimate sits 1.6-fold (0.19 log units) below what was measured; low and high end bracket the measured number.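

In this assay, among the compounds shown here, this is the first step that can be read at this position: a 1.1-fold lower number from compound 2 to compound 3 (0.03 log units; within the scatter). Vinyl, with its 2 heavy atoms and no hydrogen-bond acceptor, and furan-3-yl, with its 5 heavy atoms, one five-membered aromatic ring and 1 hydrogen-bond acceptor, cannot be told apart here on an aromatic carbon ortho to a large group and two atoms from the ring nitrogen. Between compound 2 and compound 3, then, this difference in size and ring does not separate the two numbers.

As far as these compounds go, whether an amine, a carboxylic acid or a longer chain at this place would give a step beyond the scatter stays open. Compound 1 gives only a limit and not a number, so how far the scale reaches upward cannot be read: the limit of > 100000 nM in this assay, at which 1 of the 3 values shown sits.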